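Dichloropurine analogues: effect of a second chloro on core

The source may hold more compounds than are shown below. What is called first, only, known or untested is meant among the compounds shown, and "the series" means these compounds.

Measured so far:
Compound 1 `ClCc1ccccc1Cn1cnc2c(Cl)nc(Cl)nc21`: 510 nM
Compound 2 `ClCc1cccc(Cn2cnc3ncnc(Cl)c32)c1`: 3230 nM
Compound 3 `ClCc1cccc(Cn2cnc3c(Cl)ncnc32)c1`: 3020 nM

In a functional assay on OVCAR-3 cells (Homo sapiens) for cytotoxicity, read by sulforhodamine B assay, with a stated time of 48 h (on this read-out higher numbers stand for weaker inhibition of growth and lower numbers for stronger inhibition of growth), compound 2 gives the highest number of the three. Compound 3 sits within the scatter of it, so no order between the two is claimed. Compound 1, whose core also carries two chloro groups but whose benzyl group differs as well, gives a number lower than compound 2, beyond the scatter.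

Compound 4 `ClCc1cccc(Cn2cnc3nc(Cl)nc(Cl)c32)c1` is not yet measured. It differs from compound 2 by chloro in place of hydrogen on an aromatic carbon. Within the data shown here, no single-change pair is available to size this step. Given that compound 1 with two core chloro groups gives 510 nM, a move toward a lower number is expected, of modest size, a 2.2-fold lower number from compound 2 to compound 4 (0.33 log units; beyond the scatter). Compound 4 is estimated at 1500 nM, range 500 nM to 4000 nM.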

Compound 4, concentration for total growth inhibition: 2880 nM
Estimate against measurement, compound 4: 1.9-fold (0.28 log units) below; the measured number falls inside the stated range.
By their numbers in this assay, from the lowest: compound 1; then compounds 4, 3 and 2 (each within the scatter of the next).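

In this assay, chloro in place of hydrogen on the aromatic carbon between two ring nitrogen atoms gives a 1.1-fold lower number from compound 2 to compound 4 (0.05 log units; within the scatter), so this single-change pair shows no effect of the second core chloro that can be told from the scatter. Compound 1 differs from compound 4 in more than one place, so its value cannot be assigned to this chloro. No supporting data bear on this flat step. Still open, going by these compounds, is whether an amine or a methoxy group on this same carbon would shift the number, and how far the placement of the chloromethyl group on the benzyl ring matters with the core held fixed.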